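This account rests on a few compounds, and the source may have more. Where it says the series, first, only, none or still open, it means among the compounds named here.

Measured in a functional assay on PC-3 cells (Homo sapiens) for cytotoxicity, read by MTT assay; a higher number here means a weaker inhibitor, a lower number a stronger inhibitor:
compound 1 `Cc1nc(Nc2ccc(Cl)cc2)sc1C(=O)/C=C/c1ccccc1` gives 24600 nM.
compound 2 `COc1cccc(/C=C/C(=O)c2sc(Nc3ccccc3)nc2C)c1` reaches only the limit of the assay, > 25000 nM.
compound 3 `COc1cc(/C=C/C(=O)c2sc(Nc3cccc(Cl)c3)nc2C)cc(OC)c1OC` reaches only the limit of the assay, > 25000 nM.

Compound 3 thus stands at the top of what this assay reports: its result is a limit and not a number, and it sits at the limit of > 25000 nM in this assay, at which 2 of the 3 values shown sit. Among the compounds with values here, no pair of measured compounds differs in a single place, so no measured step in this assay is available to lean on.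

Compound 4 `COc1cc(/C=C/C(=O)c2sc(Nc3ccccc3)nc2C)cc(OC)c1OC` differs from compound 3 by hydrogen in place of chloro on an aromatic carbon, in words hydrogen in place of chloro on an aromatic carbon. Among the measured compounds, compound 1 carries a chloro on its outer ring and gives 24600 nM. Compound 2 carries no chloro and sits at a limit, > 25000 nM. Neither points to a large effect of chloro in this assay. The step from compound 3 to compound 4 is therefore expected to be no more than the scatter, a step that the limit leaves unreadable from compound 3 to compound 4, in no firm direction. Compound 4 is estimated at 28000 nM, with a range from 12000 nM to 65000 nM, and a limit rather than a number is the more likely outcome.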

Compound 4, half-maximal inhibitory concentration: > 25000 nM
Compound 4 ended at the assay's limit; the forecaster's own chance of this, stated with the estimate: 70%; the middle value lies beyond the limit too.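

Compound 3 and compound 4 both sit at a limit in this assay, so the step for hydrogen in place of chloro on an aromatic carbon cannot be read. The compounds shown leave open whether this change has any effect on the read-out: the limit of > 25000 nM in this assay, at which 3 of the 4 values shown sit.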